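The source may report more compounds than this note shows. Statements on the series, on what has been measured and on what is new or still open speak of the compounds shown alone.

Measured compounds:

compound 1: `COc1ccc(/C=C/C[C@H]2C[C@H]([C@H](O)c3ccc(OC)c(OC)c3)CO[C@@H]2c2ccc(OC)c(OC)c2)cc1OC`, 34600 nM
compound 2: `COc1cccc([C@H](O)[C@H]2CO[C@H](c3ccc(OC)c(OC)c3)[C@@H](C/C=C/c3ccc(OC)c(OC)c3)C2)c1`, 21200 nM
compound 3: `COc1cccc(/C=C/C[C@@H]2C[C@@H]([C@@H](O)c3ccc(OC)c(OC)c3)CO[C@H]2c2ccc(OC)c(OC)c2)c1`, 16400 nM

In a functional assay on HeLa cells (Homo sapiens) for cytotoxicity, read by WST assay, with a stated time of 48 h (on this read-out higher numbers stand for weaker inhibition and lower numbers for stronger inhibition), compound 1 gives 34600 nM, which is the highest of the three numbers. The nearest of the others is compound 2 with 21200 nM, a gap that lies within the usual scatter of this assay, so the two cannot be told apart. The furthest is compound 3 with 16400 nM, a gap that lies just beyond the scatter, so compound 3 inhibits somewhat more strongly than compound 1.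

The next compound is compound 4, `COc1ccc(/C=C/C[C@@H]2C[C@H]([C@H](O)c3ccc(OC)c(OC)c3)CO[C@H]2c2ccc(OC)c(OC)c2)cc1OC`. Compared with compound 1: the two compounds have the same atoms and bonds and differ only in configuration as drawn: 2 of 5 stereo elements differ; a stereocentre at a saturated ring carbon is drawn S in compound 1 and R in compound 4; a stereocentre at a saturated ring carbon is drawn S in compound 1 and R in compound 4

Among the measured compounds no pair differs in one place, so there is no measured step that shows what a change of configuration at ring carbons does here. All three measured compounds sit in a narrow band of weak inhibition, and a change of configuration alone gives no clear reason to expect a departure from that band. I therefore expect a step of a 1.2-fold lower number from compound 1 to compound 4 (0.06 log units; within the scatter), in no particular direction and likely not beyond the scatter, and estimate for compound 4 a value of 30000 nM, in the range 8000 nM to 110000 nM.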

Compound 4, half-maximal inhibitory concentration: 28700 nM
Compound 4: the middle estimate sits 1.0-fold (0.02 log units) above what was measured; the measured number falls inside the stated range.
By their numbers in this assay, from the lowest: compounds 3, 2, 4 and 1 (each within the scatter of the next, the first and the last beyond it).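

Going by these compounds alone, this is the first pair that differs in one place, so a change can be read directly for the first time: the fact that compounds 1 and 4 differ only in the configuration as drawn. In this assay, changing the configuration at these two saturated ring carbons gives a 1.2-fold lower number from compound 1 to compound 4 (0.08 log units; within the scatter), so the change does not separate the two compounds. Compound 4 therefore stays in the same band of weak inhibition as compound 1, and at this level of inhibition the assay shows no preference between these two arrangements.

The compounds shown leave open whether changing the configuration at only one of these ring carbons, or at the remaining stereo elements, would have a larger effect. They also leave open what an amine or a carboxylic acid in place of the hydroxyl group would do to inhibition.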